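Pyrimidin-2-yl for Cyclopentyl on an Aromatic Nitrogen

A few compounds are considered here, and "the series" means these few. Any claim that something is new, unique, unknown or untested is made for them only; others in the source may bear on it.

Compound 1: `COCCn1nc(C(=O)N[C@H]2COc3ccccc3N(C)C2=S)nc1Cc1ccccc1`, 566 nM
Compound 2: `CN1C(=S)[C@@H](NC(=O)c2nc(Cc3ccccc3)n(C3CCCC3)n2)COc2ccccc21`, 3530 nM

In a functional assay on HT-29 cells (Homo sapiens) for inhibition, read by luminescence and CellTiter-Glo, with a stated time of 24 h (on this read-out higher numbers stand for an effect only at larger amounts of compound and lower numbers for an effect already at smaller amounts), compound 2 stands highest of the two numbers; the step of a 6.2-fold higher number from compound 1 to compound 2 (0.79 log units; beyond the scatter) separates it from compound 1. Compound 3, `CN1C(=S)[C@@H](NC(=O)c2nc(Cc3ccccc3)n(-c3ncccn3)n2)COc2ccccc21`, awaits measurement. Its change from compound 2 is pyrimidin-2-yl in place of cyclopentyl on an aromatic nitrogen. Among the measured compounds shown here, only the step from compound 1 to compound 2 touches this position, and it was modest. Pyrimidin-2-yl brings hydrogen-bond acceptors, as 2-methoxyethyl in compound 1 does and cyclopentyl does not, so a lower number is expected, though with wide uncertainty. Compound 3 is estimated at 1500 nM, between 400 nM and 6000 nM. That estimate amounts to an expected step of a 2.4-fold lower number from compound 2 to compound 3 (0.37 log units; beyond the scatter).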

Compound 3, half-maximal effective concentration: 3970 nM
Compound 3: the middle estimate sits 2.6-fold (0.42 log units) below what was measured; measured number inside the range.
By their numbers in this assay, from the lowest: compound 1; then compounds 2 and 3 (each within the scatter of the next).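

In this assay, pyrimidin-2-yl and cyclopentyl on the aromatic nitrogen cannot be told apart, with a 1.1-fold higher number from compound 2 to compound 3 (0.05 log units; within the scatter). Having hydrogen-bond acceptors on this group is therefore not enough to match 2-methoxyethyl, as the change from that chain to pyrimidin-2-yl gives a 7.0-fold higher number from compound 1 to compound 3 (0.85 log units; beyond the scatter). No measurement is available to explain this result.

From the compounds shown here alone, it remains open whether the chain in compound 1 matters through its oxygen or through its open, ring-free shape. A plain propyl chain or a 2-aminoethyl group on this nitrogen could separate those two readings.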